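The source may report more compounds than this note shows. Statements on the series, on what has been measured and on what is new or still open speak of the compounds shown alone.

Working notes on the series. Among the measured compounds shown here, in an assay on isolated protein for inhibition of Rho-associated protein kinase 2 (Homo sapiens), read by scintillation counting, radiometric assay and 33P incorporation, with a stated time of 40 min, in the presence of a further agent that is not named here (a higher number here means a weaker inhibitor, a lower number a stronger inhibitor), compound 1 `CC(=O)Nc1cccc(NC(=O)COc2ccc3c(=O)ccoc3c2)c1` gives 136 nM, and compound 2 `COc1ccc(C(=O)Nc2cccc(NC(=O)COc3ccc4c(=O)ccoc4c3)c2)cc1` gives 7 nM, which is the lowest of the two numbers so far; its nearest neighbour is compound 1, the gap being a 19-fold lower number from compound 1 to compound 2 (1.29 log units; beyond the scatter). That single step is the only one measured, and it shows that an aromatic ring on the carbonyl carbon, in place of methyl, goes with a much lower number. Compound 3 `Cc1nc(C(=O)Nc2cccc(NC(=O)COc3ccc4c(=O)ccoc4c3)c2)cs1` is not yet measured. It differs from compound 2 as follows: 2-methyl-1,3-thiazol-4-yl in place of 4-methoxyphenyl on a carbonyl carbon. For the measured compounds named here, the change keeps an aromatic ring on the same carbonyl carbon, so the step from compound 1 to compound 2 bears on it only indirectly; there is no measured pair that swaps one aromatic ring for another. The expected step of a 2.1-fold higher number from compound 2 to compound 3 (0.33 log units; beyond the scatter) is small, close to the scatter, in either direction. For compound 3 in this assay the estimate is 15 nM, with a range from 4 nM to 60 nM.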

Compound 3, half-maximal inhibitory concentration: 33 nM
For compound 3 the middle estimate is 2.2-fold (0.34 log units) below the measured one; the range from low to high includes it.
By their numbers in this assay, from the lowest: compound 2; then compound 3; then compound 1.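

In this assay, the carbonyl carbon position distinguishes one aromatic ring from another: 2-methyl-1,3-thiazol-4-yl in place of 4-methoxyphenyl gives a 4.7-fold higher number from compound 2 to compound 3 (0.67 log units; beyond the scatter), so having an aromatic ring there does not by itself give the number seen for compound 2. The 2-methyl-1,3-thiazol-4-yl ring still keeps part of the gain over methyl, with a 4.1-fold lower number from compound 1 to compound 3 (0.62 log units; beyond the scatter), and compound 3 falls between the other two compounds. Nothing on hand explains the difference between the two rings.

The compounds shown leave open how much of the 4-methoxyphenyl result belongs to the methoxy group and how much to the phenyl ring, and what the methyl contributes on the 2-methyl-1,3-thiazol-4-yl ring. They also leave open how an unsubstituted phenyl, a pyridine ring or a phenyl ring carrying an amine would compare at this position.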